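The compounds below may be only part of what the source reports. "The series", "measured", "known", "first", "only" and "open" are said of these compounds alone.

Three compounds of a shared core differing only in the benzyl group have been measured in an ADME assay on HaCaT cells (Homo sapiens) for inhibition, read by sulforhodamine B assay, with a stated time of 48 h; on this read-out higher numbers stand for weaker inhibition of growth and lower numbers for stronger inhibition of growth. Compound 1 `Brc1ccc(Cn2cc(CCCOc3cccc4cccnc34)nn2)cc1` gives 29.2 ug/mL, the highest of the three numbers. Compound 2 `Clc1cc(Cl)c(Cn2cc(CCCOc3cccc4cccnc34)nn2)c(Cl)c1` gives 5.3 ug/mL, and compound 3 `Clc1ccc(Br)cc1Cn1cc(CCCOc2cccc3cccnc23)nn1` gives 4.9 ug/mL. The step of a 5.5-fold lower number from compound 1 to compound 2 (0.74 log units; beyond the scatter) and the step of a 6.0-fold lower number from compound 1 to compound 3 (0.78 log units; beyond the scatter) both go the same way, while the step of a 1.1-fold lower number from compound 2 to compound 3 (0.03 log units; within the scatter) separates compounds 2 and 3 only within the scatter.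

Compound 4 `c1ccc(Cn2cc(CCCOc3cccc4cccnc34)nn2)cc1` is not yet measured. It differs from compound 1 by hydrogen in place of bromo on an aromatic carbon, so the 4-bromophenyl becomes an unsubstituted phenyl. The measured steps bear on this only indirectly: both add halogens to the ring bound to the saturated chain carbon and lower the number, whereas the change to compound 4 takes the single halogen away. Among the measured compounds shown here, no measured step removes a halogen, so the expectation rests on the direction seen: if more halogens lower the number, fewer may raise it, though possibly not beyond the scatter. Compound 4 is therefore expected to give a number near or somewhat above that of compound 1, estimated at 40 ug/mL with a range from 15 ug/mL to 100 ug/mL, corresponding to an expected step of a 1.4-fold higher number from compound 1 to compound 4 (0.14 log units; within the scatter).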

Compound 4, concentration for 50% growth inhibition: 12.7 ug/mL
Compound 4: the middle estimate sits 3.1-fold (0.50 log units) above what was measured; measured number outside the range, below it.
By their numbers in this assay, from the lowest: compounds 3 and 2 (each within the scatter of the next); then compound 4; then compound 1.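

In this assay, among the compounds shown here, the change from 4-bromophenyl to phenyl gives a 2.3-fold lower number from compound 1 to compound 4 (0.36 log units; beyond the scatter) and so shows that the single bromo on this aromatic carbon goes with the higher number, not the lower one, which the earlier steps alone could not reveal. The phenyl does not match the two rings with more halogens, with a 2.6-fold higher number from compound 3 to compound 4 (0.41 log units; beyond the scatter) and a 2.4-fold higher number from compound 2 to compound 4 (0.38 log units; beyond the scatter) marking the gap, so the ring without halogen lies inside the series, and the number of halogens does not order these compounds: compound 1, with its one bromo, goes against any such trend, since it stands above compound 4, which has none. Nothing at hand gives a reason for this order.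

The compounds shown leave open whether the higher number of compound 1 belongs to bromo itself or to any group on that aromatic carbon, which a 4-chlorophenyl, a 4-fluorophenyl or a 4-methoxyphenyl would help to settle. They also leave open how an amine or a carboxylic acid on the same ring would read, and which of the halogens in compound 2 and compound 3 carry the lower numbers.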